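Indole Replaces Methoxyphenyl on a Triazole-Coumarin Scaffold

This account rests on a few compounds, and the source may have more. Where it says the series, first, only, none or still open, it means among the compounds named here.

Measured compounds:
compound 1 `COc1ccc(-c2cn(-c3cc4ccc(O)c(C)c4oc3=O)nn2)cc1` — in a functional assay on MCF7 cells (Homo sapiens) for antiproliferative activity (a higher number here means a weaker inhibitor, a lower number a stronger inhibitor), compound 1 gives > 100000 nM
compound 2 `COc1cccc(-c2cc(-c3cn(-c4cc5ccc(O)c(C)c5oc4=O)nn3)ccc2OC)c1` — in this assay compound 2 gives 28000 nM

Compound 1 stands at the edge of the measured range: its result in this assay is a limit of the assay, not a number (the limit of > 100000 nM in this assay, at which 1 of the 2 values shown sits). For the measured compounds named here, the only step measured from it is an at least 3.5-fold lower number from compound 1 to compound 2 (0.55 log units; beyond the scatter), where a 3-methoxyphenyl group was added onto the existing aryl ring. Compound 3 `Cc1c(O)ccc2cc(-n3cc(-c4c[nH]c5ccccc45)nn3)c(=O)oc12` differs from compound 1 in another way: 1H-indol-3-yl in place of 4-methoxyphenyl on an aromatic carbon. Going by the values given here, no measured step removes or replaces the 4-methoxyphenyl group, so the single step to compound 2 bears on compound 3 only indirectly, showing that the core tolerates change at this position and can gain in this assay. A step of an at least 2.0-fold lower number from compound 1 to compound 3 (0.30 log units; that floor lies within the scatter) is expected, toward a measurable number. Compound 3 is estimated at 50000 nM, with a range from 10000 nM to 200000 nM.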

Compound 3, half-maximal inhibitory concentration: 8170 nM
For compound 3 the middle estimate is 6.1-fold (0.79 log units) above the measured one; the measured number lies below the stated range.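

Replacing the 4-methoxyphenyl group itself, on an aromatic carbon of the five-membered aromatic ring with 3 nitrogen, gives an at least 12-fold lower number from compound 1 to compound 3 (1.08 log units; beyond the scatter) in this assay and so counts as a large step. The earlier step kept the 4-methoxyphenyl ring and built onto it, whereas this one shows that the ring can be exchanged outright for 1H-indol-3-yl and a measurable number still results. From the compounds shown here alone, the true size of the step stays unknown because compound 1 stands at a limit of the assay, so the printed step is only a floor: the limit of > 100000 nM in this assay, at which 1 of the 3 values shown sits.

The compounds shown do not separate the part played by the indole ring hydrogen on nitrogen from that of the second ring. A 1-methylindol-3-yl group, a plain phenyl or a 4-aminophenyl at this place would bear on that question.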